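Swapping Trifluoromethoxy for Dichloro on the Pendant Ring

The source may report more compounds than this note shows. Statements on the series, on what has been measured and on what is new or still open speak of the compounds shown alone.

Three compounds share one core and differ only on a pendant phenyl ring: compound 1 `CC/C(=C(/c1ccc(/C=C/C(=O)O)cc1)c1cc2ccccc2[nH]1)c1ccccc1`, compound 2 `CC/C(=C(/c1ccc(/C=C/C(=O)O)cc1)c1cc2ccccc2[nH]1)c1cccc(C)c1` and compound 3 `CC/C(=C(/c1ccc(/C=C/C(=O)O)cc1)c1cc2ccccc2[nH]1)c1cccc(OC(F)(F)F)c1`. In a functional assay on MCF7 cells (Homo sapiens) for inhibition (on this read-out lower numbers stand for stronger inhibition and higher numbers for weaker inhibition), compound 1 gives 108 nM, compound 2 gives 140 nM, and compound 3 gives 282 nM, the highest number of the three, though its gap to compound 2 lies within the scatter, as a 2.0-fold higher number from compound 2 to compound 3 (0.30 log units; within the scatter) and a 2.6-fold higher number from compound 1 to compound 3 (0.42 log units; beyond the scatter) show. Compound 4 `CC/C(=C(/c1ccc(/C=C/C(=O)O)cc1)c1cc2ccccc2[nH]1)c1cccc(Cl)c1Cl` carries 2,3-dichlorophenyl in place of 3-(trifluoromethoxy)phenyl on a double-bonded chain carbon bound to a double-bonded chain carbon and a saturated chain carbon. The earlier changes at this place, a 1.3-fold higher number from compound 1 to compound 2 (0.11 log units; within the scatter) and a 2.6-fold higher number from compound 1 to compound 3 (0.42 log units; beyond the scatter), raised the number at most modestly, so the expected step is small and without clear direction: a 1.1-fold higher number from compound 3 to compound 4 (0.03 log units; within the scatter). Compound 4 is therefore estimated at 300 nM, within a range from 100 nM to 900 nM.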

Compound 4, half-maximal inhibitory concentration: 898 nM
For compound 4 the middle estimate is 3.0-fold (0.48 log units) below the measured one; the range from low to high includes it.
By their numbers in this assay, from the lowest: compounds 1, 2 and 3 (each within the scatter of the next, the first and the last beyond it); then compound 4.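

In this assay the 2,3-dichlorophenyl group brings a 3.2-fold higher number from compound 3 to compound 4 (0.50 log units; beyond the scatter) and a 6.4-fold higher number from compound 2 to compound 4 (0.81 log units; beyond the scatter) and also an 8.3-fold higher number from compound 1 to compound 4 (0.92 log units; beyond the scatter) and so moves the number further than any earlier change at this place. Compound 4 alone stands beyond the scatter from every other compound, so this place does not accept every substituted phenyl ring equally. On these data alone, whether a phenyl ring carrying a single chlorine or an amine would keep the number close to that of compound 1 stays open. Nothing measured here says why the 2,3-dichlorophenyl group gives this result.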